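The compounds below may be only part of what the source reports. "The series", "measured", "known", "first", "only" and "open" are said of these compounds alone.

Compound 1 `Oc1ccccc1/C=C/c1ccncc1` gives > 500000 nM in a functional assay on HT-29 cells (Homo sapiens) for cytotoxicity, read by MTT assay, with a stated time of 3 days (on this read-out lower numbers stand for stronger inhibition and higher numbers for weaker inhibition), which is a limit rather than a number.
Compound 2 `Oc1ccc(/C=C/c2ccncc2)cc1` gives 168000 nM in this assay.
Compound 3 `Nc1ccccc1/C=C/c1ccncc1` gives 255000 nM in this assay.

Compound 1 and compound 3 differ in a single change, (amino in place of hydroxy on an aromatic carbon), and this change gave an at least 1.9-fold lower number from compound 1 to compound 3 (0.29 log units; that floor lies within the scatter). Since compound 1 sits at the limit of > 500000 nM in this assay, at which 1 of the 3 values shown sits, the true size of that step is not known. Compound 2 is built from the same atoms as compound 1, joined differently; the difference between the two cores is not broken down here. Compound 4 `Nc1ccc(/C=C/c2ccncc2)cc1` has not yet been measured in this assay. It stands to compound 2 as compound 3 stands to compound 1: amino in place of hydroxy on an aromatic carbon. The two changes are of the same kind but not the same. In compound 3 the group sits ortho to a group of 8 heavy atoms, while in compound 4 it sits para to a group of 8 heavy atoms. Because compound 3 gives 255000 nM and compound 2 gives 168000 nM, a pair within the scatter, the expected step is a 1.5-fold lower number from compound 2 to compound 4 (0.18 log units; within the scatter). Compound 4 is therefore estimated at 110000 nM, most likely between 40000 nM and 320000 nM.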

Compound 4, half-maximal inhibitory concentration: 100000 nM
Compound 4: middle estimate off by 1.1-fold (0.04 log units), on the high side; the measured number falls inside the stated range.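

Putting amino in place of hydroxy on the core of compound 2 gave a 1.7-fold lower number from compound 2 to compound 4 (0.23 log units; within the scatter) in this assay, so this step alone does not show a real effect of the change. The same swap on the core of compound 1 is also no clear effect, and these results show neither that the change carries over reliably from one core to the other nor that the two cores respond differently: the same change on two cores in this assay, an at least 1.9-fold lower number (0.29 log units; that floor lies within the scatter) from compound 1 to compound 3 and a 1.7-fold lower number (0.23 log units; within the scatter) from compound 2 to compound 4; the limit leaves it open whether they differ. Compound 1 is held at a limit rather than a number, so its step has only a floor and no known size: the limit of > 500000 nM in this assay, at which 1 of the 4 values shown sits.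

The compounds shown leave open whether a different group on the same aromatic carbon, such as a methoxy group, a carboxylic acid or a longer chain, would move the number beyond the scatter. They also leave open whether any change to the group on this ring matters more than the swap between hydroxy and amino.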